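The source may report more compounds than this note shows. Statements on the series, on what has been measured and on what is new or still open speak of the compounds shown alone.

The measured compounds, each with its value:
Compound 1 `COc1cccc(S(=O)(=O)Nc2ccc3oc(-c4ccccc4)nc3c2)c1` gives in an assay on cells for inhibition of HSP60/HSP10 (Homo sapiens), with a stated time of 60 min (on this read-out lower numbers stand for stronger inhibition and higher numbers for weaker inhibition), a value of > 100000 nM, which is a limit of the assay and not a number.
Compound 2 `O=S(=O)(Nc1ccc(-c2nc3ccccc3o2)cc1)c1cccc(O)c1` gives 62000 nM.
Compound 3 `O=S(=O)(Nc1ccc(-c2nc3ccccc3o2)cc1)c1ccc(F)cc1` gives 73000 nM.

On the numbers shown, compound 1 stands apart: it is the only compound for which the assay reports a limit rather than a number (the limit of > 100000 nM in this assay, at which 1 of the 3 values shown sits). Compounds 2 and 3 carry numbers lying close to one another, the step between them being a 1.2-fold higher number from compound 2 to compound 3 (0.07 log units; within the scatter); these two share a core of their own that differs from the core of compound 1.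

Compound 4 `O=S(=O)(Nc1ccc2oc(-c3ccccc3)nc2c1)c1cccc(Cl)c1` differs from compound 1 by chloro in place of methoxy on an aromatic carbon. For the measured compounds named here, no measured step covers an exchange of chloro for methoxy. Going by the values given here, the only measured step, a 1.2-fold higher number from compound 2 to compound 3 (0.07 log units; within the scatter), concerns other groups on another core and lay within the scatter, so it offers no direction for this change. Compound 4 is therefore expected to give a weak value, estimated at 90000 nM with a range from 40000 nM to 200000 nM. The step of an at least 1.1-fold lower number from compound 1 to compound 4 (0.04 log units; that floor lies within the scatter) is expected to stay within the scatter, with a fair chance that the assay again reports only a limit.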

Compound 4, half-maximal inhibitory concentration: > 100000 nM
Compound 4: no number, only a limit; the forecaster's own chance of this, stated with the estimate: 45%; at least 1.1-fold (0.04 log units) between middle value and limit.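

In this assay compound 4 gives > 100000 nM, which is a limit of the assay and not a number. For the compounds shown here, compound 1 also sits at a limit, so no step between compound 1 and compound 4 can be read. The compounds shown leave open how chloro and methoxy compare on this core.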